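The source may report more compounds than this note shows. Statements on the series, on what has been measured and on what is new or still open speak of the compounds shown alone.

Three measured compounds share one core and differ only in the group on the carbonyl carbon. Compound 1 `COc1ccc(N)c(C2=NN(C(C)=O)C(C)(C)S2)c1` gives 77.1% in an assay on isolated protein for inhibition of Nitric oxide synthase, inducible (Homo sapiens), read by scintillation counting, with a stated time of 30 min, tested at 50 uM; a lower number here means less inhibition, a higher number more inhibition at the concentration tested (going by the name of the read-out). Compound 2 `CCC(=O)N1N=C(c2cc(OC)ccc2N)SC1(C)C` gives 73% in this assay, and compound 3 `COc1ccc(N)c(C2=NN(C(=O)C3CC3)C(C)(C)S2)c1` gives 90.1% in this assay. Among these three numbers compound 2 stands lowest; its nearest neighbour is compound 1, with a step within the scatter, a number 4.1 percentage points lower from compound 1 to compound 2 (within the scatter), and its furthest is compound 3, a number 17.1 percentage points higher from compound 2 to compound 3 (beyond the scatter). The remaining step, a number 13 percentage points higher from compound 1 to compound 3 (beyond the scatter), is likewise beyond the scatter.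

Compound 4 `CCC(=O)N1N=C(c2ccccc2N)SC1(C)C` differs from compound 2 in another place altogether: hydrogen in place of methoxy on an aromatic carbon. For the measured compounds named here, none of the three measured steps concerns the aromatic ring; each of them changes the group on the carbonyl carbon, so no measured step bears directly on this change. The three steps show that the read-out in this assay moves by modest amounts for small changes, and with no guide for the aromatic position the expected step from compound 2 to compound 4 is a modest downward move or none beyond the scatter, a number 11 percentage points lower from compound 2 to compound 4 (beyond the scatter). Compound 4 is therefore expected to give 62% in this assay, within a wide range from 38% to 84%.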

Compound 4, a percentage reported as inhibition, at one concentration (the size of the read-out at that concentration, not a potency): 19.2%
Compound 4: middle estimate off by 42.8 percentage points, on the high side, outside the stated range (below it).
By their numbers in this assay, from the lowest: compound 4; then compounds 2 and 1 (each within the scatter of the next); then compound 3.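

At this place, on an aromatic carbon para to an amino group, hydrogen in place of methoxy brings in this assay a number 53.8 percentage points lower from compound 2 to compound 4 (beyond the scatter) and so ranks as a large step. The earlier compounds shown here all carry the methoxy and differ only in the group on the carbonyl carbon, where no step was more than modest, so they gave no sign that the aromatic ring could weigh far more heavily on this read-out. Compound 4 shows that, at least with the ethyl group of compound 2 on the carbonyl carbon, hydrogen cannot stand in for methoxy here without a large fall in inhibition, and nothing shown accounts for the size of this step.

Going by these compounds, whether the methoxy itself is what counts remains open, and an ethoxy group, a hydroxy group or a chlorine atom at the same place would begin to separate that from the mere presence of a group there. On these data alone, it also remains open whether the same fall would follow with the methyl of compound 1 or the cyclopropyl of compound 3 on the carbonyl carbon.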